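Working notes: compound 1 to compound 4

The source may report more compounds than this note shows. Statements on the series, on what has been measured and on what is new or still open speak of the compounds shown alone.

- compound 1 `CC(=O)SCCC(CCCCC(=O)O)SC(C)=O` gives "not active" (no number reported)
- compound 2 `O=C(CCCCC(S)CCS)Nc1ccccc1` gives 7.37%
- compound 3 `O=C(CCCCC(S)CCS)Nc1ccc([N+](=O)[O-])cc1` gives "not active" (no number reported)
- compound 4 `CC(=O)SCCC(CCCCC(=O)Nc1ccccc1)SC(C)=O` is not yet measured

All three measured compounds were run in a functional assay on HO8910 cells (Homo sapiens) for inhibition, read by MTT assay, with a stated time of 24 h, tested at 0.1 ug/mL; on this read-out higher numbers stand for more inhibition of growth at the one concentration tested and lower numbers for less inhibition of growth. Compound 1 has no single number on this read-out and was reported only as inactive. For the measured compounds named here, compound 3 is the one other entry without a number, so compound 2 is the only member of the series with a numerical value. Going by the values given here, no step between measured compounds can therefore be calculated, and the position of compound 1 cannot be put on a numerical scale.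

The change under consideration is anilino in place of hydroxy on a carbonyl carbon. The rest of the core of compound 1 stays as it is. In this assay the expected step is small, with no rise beyond the scatter. The nearest evidence is compound 2, which also carries anilino on a carbonyl carbon and reaches only 7.37% at the single concentration tested. It differs from compound 4 elsewhere in the structure, so this comparison is only a rough guide. A report without a number also remains a real possibility for compound 4. For compound 4 the expected inhibition is 6%, with an estimated range from 0% to 16%.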

Compound 4, percent growth inhibition at one concentration: 8.33%
Estimate against measurement, compound 4: 2.3 percentage points below; the measured number falls inside the stated range.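

In this assay compound 1 ("not active" (no number reported)) and compound 4 (8.33%) give no readable step: only compound 4 of the two carries a number. The compounds shown leave open how large any effect of anilino in place of hydroxy on a carbonyl carbon is in this assay and at other concentrations. No evidence on the result is available here.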